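The compounds below may be only part of what the source reports. "The series", "measured", "known", "first", "only" and "open" are said of these compounds alone.

- compound 1 `CCn1c(C(=O)NCCO)ccc1C(CC)(CC)c1ccc(OCS(=O)(=O)c2ccccc2)c(C)c1`: 17700 nM
- compound 2 `CCn1c(C(=O)NCCCO)ccc1C(CC)(CC)c1ccc(OCS(=O)(=O)c2ccccc2)c(C)c1`: 11300 nM

For the measured compounds named here, in a functional assay on PC-3 cells (Homo sapiens) for antiproliferative activity, read by MTT assay, with a stated time of 24 h (on this read-out lower numbers stand for stronger inhibition and higher numbers for weaker inhibition), compound 2 stands at 11300 nM, level with the only other measured compound within the scatter. Compound 3 `CCn1c(C(=O)N[C@H](CO)CCO)ccc1C(CC)(CC)c1ccc(OCS(=O)(=O)c2ccccc2)c(C)c1` differs from compound 2 by hydroxymethyl in place of hydrogen on a saturated chain carbon bound to an amide-type nitrogen and a saturated chain carbon. Going by the values given here, no measured step shows this exact change. The closest is a 1.6-fold lower number from compound 1 to compound 2 (0.19 log units; within the scatter), which also adds to the same chain, so no step beyond the scatter is expected in this assay, in either direction. The expected step is a 1.1-fold higher number from compound 2 to compound 3 (0.03 log units; within the scatter). Compound 3 is estimated at 12000 nM, with an expected range from 5500 nM to 26000 nM.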

Compound 3, half-maximal inhibitory concentration: 12100 nM
The estimate for compound 3 lay 1.0-fold (0.00 log units) below the measured number; the range from low to high includes it.
By their numbers in this assay, from the lowest: compounds 2, 3 and 1 (each within the scatter of the next).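

Hydroxymethyl in place of hydrogen on the saturated chain carbon bound to an amide-type nitrogen gives in this assay the step of a 1.1-fold higher number from compound 2 to compound 3 (0.03 log units; within the scatter) and shows that this carbon takes a branch with no step beyond the scatter. Read against the shorter chain, 2-hydroxyethyl in place of hydrogen at that carbon gives a 1.5-fold lower number from compound 1 to compound 3 (0.17 log units; within the scatter) and that step also stays within the scatter. No evidence on this series bears on the result.

The compounds shown leave open whether an amine or a carboxylic acid in place of the hydroxy on this chain, or a longer chain, would move the number beyond the scatter.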